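This account rests on a few compounds, and the source may have more. Where it says the series, first, only, none or still open, it means among the compounds named here.

Of the compounds shown here, three of one series have been measured in a functional assay on PC-3 cells (Homo sapiens) for inhibition, read by sulforhodamine B assay; on this read-out lower numbers stand for stronger inhibition of growth and higher numbers for weaker inhibition of growth. Compound 1 `Clc1cccc(-c2ccc(-c3ccc(-c4nc5ccccc5[nH]4)cc3)cc2)c1` gives 33700 nM in this assay. Compound 2 `COc1ccc(-c2ccc(-c3ccc(-c4nc5ccccc5[nH]4)cc3)cc2)cc1OC` differs from compound 1 by a single change, (3,4-dimethoxyphenyl in place of 3-chlorophenyl on an aromatic carbon), and in this assay compound 2 gives 47100 nM; the step is a 1.4-fold higher number from compound 1 to compound 2 (0.15 log units; within the scatter), so the two numbers cannot be told apart. Compound 3 `Oc1cccc2[nH]c(-c3ccc(-c4ccc(-c5cccc(Cl)c5)cc4)cc3)nc12` keeps the 3-chlorophenyl of compound 1 but differs in its core by hydroxy in place of hydrogen on an aromatic carbon; in this assay compound 3 gives 2560 nM, and the step is a 13-fold lower number from compound 1 to compound 3 (1.12 log units; beyond the scatter). Compound 3 thus stands well apart from both compound 1 and compound 2.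

Compound 4 `COc1ccc(-c2ccc(-c3ccc(-c4nc5c(O)cccc5[nH]4)cc3)cc2)cc1OC` has not yet been measured. It is built on the core of compound 3 and differs from compound 3 by 3,4-dimethoxyphenyl in place of 3-chlorophenyl on an aromatic carbon. Going by the values given here, this is the same change as the one from compound 1 to compound 2, made at the same place, and that earlier step was a 1.4-fold higher number from compound 1 to compound 2 (0.15 log units; within the scatter). Among the compounds with values here, on the core of compound 3 there is only this one precedent to rest on, and the core of compound 4 is not that of compound 1, so the step from compound 3 to compound 4 is expected to be of similar small size, a 1.4-fold higher number from compound 3 to compound 4 (0.15 log units; within the scatter), because the earlier step of a 1.4-fold higher number from compound 1 to compound 2 (0.15 log units; within the scatter) was small. Compound 4 is therefore expected to give about 3600 nM in this assay, with a likely range from 1400 nM to 9500 nM.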

Compound 4, concentration for 50% growth inhibition: 1240 nM
Beside the measured number, compound 4's estimate is 2.9-fold (0.46 log units) above it, outside the stated range (below it).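

In this assay, the swap of 3-chlorophenyl for 3,4-dimethoxyphenyl on the hydroxy-bearing core gives a 2.1-fold lower number from compound 3 to compound 4 (0.31 log units; beyond the scatter) and so does not carry over unchanged from the core of compound 1, where the same swap made no difference that could be told from scatter: the same change on two cores in this assay, a 1.4-fold higher number (0.15 log units; within the scatter) from compound 1 to compound 2 and a 2.1-fold lower number (0.31 log units; beyond the scatter) from compound 3 to compound 4, 2.9-fold (0.46 log units) apart, beyond the scatter of two such steps. Read along the other edge of the same four compounds, hydroxy in place of hydrogen lowers the number on both sides, with a 38-fold lower number from compound 2 to compound 4 (1.58 log units; beyond the scatter) as the larger of the two steps: the same change on two cores in this assay, a 13-fold lower number (1.12 log units; beyond the scatter) from compound 1 to compound 3 and a 38-fold lower number (1.58 log units; beyond the scatter) from compound 2 to compound 4, 2.9-fold (0.46 log units) apart, beyond the scatter of two such steps. The two gaps are one observation seen from two sides, showing that in these four compounds the two changes do not simply add; they do not show why, and one pair of cores does not establish how the swap would behave on any other core in the series.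

The compounds shown leave open whether a methoxy or an amine in place of the hydroxy would keep the lower numbers, and whether a carboxylic acid on the terminal ring would follow either of the two aryl groups. They also leave open whether the same gap between cores would appear for any other pair of groups at that place.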